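Propyl in place of pyridin-3-yl: working notes

This account rests on a few compounds, and the source may have more. Where it says the series, first, only, none or still open, it means among the compounds named here.

Measured in a functional assay on MCF7 cells (Homo sapiens) for cytotoxicity, read by WST assay, with a stated time of 72 h; on this read-out higher numbers stand for weaker inhibition and lower numbers for stronger inhibition:
- compound 1 `COc1ccc(C2(c3ccc(O)cc3)C(=O)Nc3c2ccc(F)c3F)cc1`: 2.1 nM; 6.3 nM; > 1000 nM (3 entries)
- compound 2 `O=C1Nc2c(ccc(F)c2F)C1(c1ccc(O)cc1)c1cccnc1`: 63 nM

Among the measured compounds shown here, compound 2, at 63 nM, is the only compound with a single number in this assay. Compound 1 has no single number: the several entries of compound 1 in this assay, 2.1 nM; 6.3 nM; > 1000 nM (3 entries). One of these entries of compound 1 is a limit of the assay, not a number. Its two numeric entries are lower than the value of compound 2, but their spread leaves that comparison weak.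

Compound 3 `CCCC1(c2ccc(O)cc2)C(=O)Nc2c1ccc(F)c2F` keeps the core of compound 2 and changes one group: propyl in place of pyridin-3-yl on a saturated ring carbon. For the measured compounds named here, no two measured compounds differ in one place alone, so no measured step gauges this change. Compound 1 and compound 2 (63 nM) both carry a ring at this place and propyl brings none, so a modest loss is expected in this assay, held loosely. The estimated step is a 2.4-fold higher number from compound 2 to compound 3 (0.38 log units; beyond the scatter), towards weaker inhibition. For compound 3 the estimated value is 150 nM, with an expected range of 25 nM to 900 nM.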

Compound 3, half-maximal inhibitory concentration: > 1000 nM
Compound 3: only a limit was reported (the forecaster's own chance of this, stated with the estimate: 10%); at least 6.6-fold (0.82 log units) between middle value and limit.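

In this assay compound 3 gives > 1000 nM, which is a limit of the assay and not a number. Among the compounds shown here, the series now has its only measured step at this saturated ring carbon, an at least 15-fold higher number from compound 2 to compound 3 (1.20 log units; beyond the scatter), so this place does not tolerate every group: propyl in place of pyridin-3-yl moves the read-out towards weaker inhibition, and how far beyond the printed step it goes cannot be told. The data give no cause for this loss, and the reading needs some care since the same limit also occurs elsewhere in the series: the limit of > 1000 nM in this assay, at which 1 of the 3 values shown sits.

The compounds shown leave open whether a ring at this place is what counts, and whether a saturated ring such as cyclohexyl, or a longer chain such as hexyl, would read like pyridin-3-yl or like propyl. On these data alone, compound 1 has no single number in this assay, so how the ring it carries at this place ranks against pyridin-3-yl and propyl also stays open.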